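From benzyloxycarbonyl to carboxy on compound 1

The compounds below may be only part of what the source reports. "The series", "measured", "known", "first", "only" and "open" are said of these compounds alone.

Values from a functional assay on the whole organism with Rattus norvegicus as the target (a higher number here means that more compound is needed for the effect, a lower number that less compound is needed), stand below

- Compound 1 `O=C(Nc1nc(-c2cc(-c3c(F)cccc3Cl)no2)cs1)C(=O)OCc1ccccc1` gives > 30 mg/kg (a limit)
- Compound 2 `CCOCCOC(=O)C(=O)Nc1nc(-c2c(-c3ccccc3)noc2C)cs1` gives > 100 mg/kg (a limit)
- Compound 3 `CCOCCOC(=O)C(=O)Nc1nc(-c2cc(C)on2)cs1` gives 2 mg/kg (a number)

Compound 1 has no number, only the limit > 30 mg/kg in this assay as its reading. Compound 2 likewise has only a limit, > 100 mg/kg as its reading. Among the compounds with values here, compound 3 carries the one true number of the three, 2 mg/kg in this assay as its reading.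

Compound 4 (`O=C(O)C(=O)Nc1nc(-c2cc(-c3c(F)cccc3Cl)no2)cs1`) differs from compound 1 by hydrogen in place of benzyl on an oxygen next to a carbonyl group and so has hydrogen in place of benzyl on an oxygen next to a carbonyl group, which reads as benzyloxycarbonyl to carboxy. Within the data shown here, no measured pair here shows this change, so any expectation for it is loose. The step of an at least 1.5-fold lower number from compound 1 to compound 4 (0.17 log units; that floor lies within the scatter) is expected to point towards less compound needed, though only modestly, and another limit would be no surprise. A real number remains possible as well. Compound 3 reaches 2 mg/kg in this assay on the same shared core. Compound 4 is estimated at 20 mg/kg (expected range 2 mg/kg to 100 mg/kg).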

Compound 4, dose for half-maximal effect: > 30 mg/kg
Compound 4 was reported as a limit (the forecaster's own chance of this, stated with the estimate: 45%); at least 1.5-fold (0.17 log units) between middle value and limit.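

In this assay, no step can be read between compound 1 and compound 4, because both readings are the same limit and not numbers: the limit of > 30 mg/kg in this assay, at which 2 of the 4 values shown sit. The compounds shown leave open whether benzyloxycarbonyl to carboxy changes the dose needed on this shared core, and in which direction.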